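Working notes: three ethers and one anilino analogue

The source may hold more compounds than are shown below. What is called first, only, known or untested is meant among the compounds shown, and "the series" means these compounds.

Measured compounds:
Compound 1 `CC(C)Oc1cc(=O)oc2cc(OCc3cccc(Cl)c3)ccc12` gives 3% in an assay on isolated protein (strain Sprague-Dawley) for inhibition of Amine oxidase [flavin-containing] A (Rattus norvegicus), read by spectrophotometry, with a stated time of 5 min, tested at 10 uM; a higher number here means more inhibition at the concentration tested (going by the name of the read-out), a lower number less inhibition.
Compound 2 `CN(C)C(=O)COc1cc(=O)oc2cc(OCc3cccc(Cl)c3)ccc12` gives 10% in this assay.
Compound 3 `O=C(COc1cc(=O)oc2cc(OCc3cccc(Cl)c3)ccc12)N1CCCCC1` gives 9% in this assay.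

Compound 3 stands second highest of the three numbers; its nearest neighbour shows a number 1 percentage points lower from compound 2 to compound 3 (within the scatter), its furthest a number 6 percentage points higher from compound 1 to compound 3 (within the scatter), both within the scatter. Compound 4 `O=c1cc(Nc2ccccc2)c2ccc(OCc3cccc(Cl)c3)cc2o1` differs from it: anilino in place of ((piperidin-1-yl)carbonyl)methoxy on an aromatic carbon. The measured steps, a number 7 percentage points higher from compound 1 to compound 2 (within the scatter) and a number 6 percentage points higher from compound 1 to compound 3 (within the scatter), all exchange one group on the ring oxygen for another and keep that oxygen; none replaces it by anilino, so they bear on the change only loosely. They show no movement beyond the scatter, and none is expected here: compound 4 is estimated at 12% (range 0% to 35%), a step of a number 3 percentage points higher from compound 3 to compound 4 (within the scatter) that is expected to stay within the scatter.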

Compound 4, a percentage reported as inhibition, at one concentration (the size of the read-out at that concentration, not a potency): 0%
The estimate for compound 4 lay 12 percentage points above the measured number; low and high end bracket the measured number.
By their numbers in this assay, from the lowest: compounds 4, 1, 3 and 2 (each within the scatter of the next).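

Anilino at this position, opposite the ring oxygen, gives no shift beyond the scatter in this assay: a number 9 percentage points lower from compound 3 to compound 4 (within the scatter) and a number 10 percentage points lower from compound 2 to compound 4 (within the scatter) and a number 3 percentage points lower from compound 1 to compound 4 (within the scatter) are all within it. The earlier steps shown here all kept the ring oxygen, whereas these replace it with the nitrogen of anilino and still leave all four compounds within the scatter of one another. No supporting measurement accompanies this result, so its cause stays unaddressed.

Still open, going by these compounds, is whether a carboxylic acid or a primary amine on the chain at this position would give a number beyond the scatter of these four. The same holds for a chloro substituent on the anilino ring.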